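Isopropyl traded for a large two-ring group

A few compounds are considered here, and "the series" means these few. Any claim that something is new, unique, unknown or untested is made for them only; others in the source may bear on it.

- Compound 1 `CNC(=O)Nc1ccc(-c2nc(N3CC4CCC(C3)O4)c3cnn(C(C)C)c3n2)cc1` gives 0.2 h
- Compound 2 `O=C(Nc1ccc(-c2nc(N3CC4CCC(C3)O4)c3cnn(C4CCC5(CC4)OCCO5)c3n2)cc1)Nc1cccnc1` gives 0.217 h
- Compound 3 `CCNC(=O)Nc1ccc(-c2nc(N3CC4CCC(C3)O4)c3cnn(C4CCC5(CC4)OCCO5)c3n2)cc1` gives 0.167 h

These numbers all come from an in vitro ADME assay on microsomes (Homo sapiens) for metabolic stability (a lower number here means that the compound disappears faster, a higher number that the compound lasts longer), and lie within the usual scatter of one another, so compound 1 stands level with compound 2 and compound 3, with no real order among them.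

The open case is compound 4 `CNC(=O)Nc1ccc(-c2nc(N3CC4CCC(C3)O4)c3cnn(C4CCC5(CC4)OCCCO5)c3n2)cc1` which differs from compound 1 in one place, on an aromatic nitrogen of the shared core. The change is a group of 11 heavy atoms (9 carbon, 2 oxygen; one six-membered non-aromatic ring of carbon only, one six-membered non-aromatic ring with 2 hetero atoms) in place of a group of 3 heavy atoms (3 carbon; no ring), on an aromatic nitrogen and it replaces the isopropyl group.

Within the data shown here, the only measured step is a 1.3-fold lower number from compound 2 to compound 3 (0.11 log units; within the scatter) and it lies within the scatter, but it concerns an amide-type nitrogen, not this aromatic nitrogen. Among the measured compounds shown here, no measured step covers the change directly. There is indirect evidence, though. Compound 1 carries isopropyl there and gives 0.2 h while compound 3 carries a closely related large group there and gives 0.167 h and these two values sit within the scatter of each other.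

No move beyond the scatter is therefore expected, in either direction. The estimated step is a 1.1-fold lower number from compound 1 to compound 4 (0.05 log units; within the scatter) and it is expected to stay inside that scatter. For compound 4 the estimate is 0.18 h and the expected range runs from 0.1 h to 0.33 h around it.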

Compound 4, half-life: > 0.5 h
Compound 4 ended at the assay's limit; the forecaster's own chance of this, stated with the estimate: 5%; middle value at least 2.7-fold (0.44 log units) from the limit.
By their numbers in this assay, from the lowest: compounds 3, 1 and 2 (each within the scatter of the next). At a limit, above all of these: compound 4.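

Among these compounds, replacing the isopropyl group on this aromatic nitrogen with the larger two-ring group gives an at least 2.5-fold higher number from compound 1 to compound 4 (0.39 log units; beyond the scatter), the first measured step at this position, and it shows that the compound lasts longer after the change. The earlier compounds shown here could not show this, as none of their steps concerned this nitrogen, so the position could have been one where the group made no real difference. In this assay compound 4 gives > 0.5 h, which is a limit of the assay and not a number, so the step sets only a lower bound and its true size stays unknown: the limit of > 0.5 h in this assay, at which 1 of the 4 values shown sits.

Going by these compounds, this single step cannot separate the two parts of the entering group, so it stays open whether a plain cyclohexyl group on this nitrogen, with the carbon-only ring alone, would give a similar result or whether the ring holding the two oxygens is needed. On these data alone, it is also open how an amine or a carboxylic acid on the carbon-only ring would behave in this assay, and whether the step would look the same on a core with a different group at the other end of the molecule.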